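A Fluoropyridine Swap in a Fluorophenyl Pair

The source may hold more compounds than are shown below. What is called first, only, known or untested is meant among the compounds shown, and "the series" means these compounds.

In a functional assay on SW480 cells (Homo sapiens) for antiproliferative activity, read by sulforhodamine B assay, with a stated time of 48 h (a higher number here means a weaker inhibitor, a lower number a stronger inhibitor), compound 1 `COc1ccc(/C=C/C(=O)c2ccccc2-c2ccc(F)cc2)cc1` gives 61 nM, while compound 2 `COc1ccc(/C=C/C(=O)c2ccccc2-c2cccc(F)c2)cc1` gives 140 nM. Compound 2 therefore holds the higher of the two numbers and is the weaker inhibitor. Compound 3 `COc1ccc(/C=C/C(=O)c2ccccc2-c2ccc(F)nc2)cc1` carries 6-fluoropyridin-3-yl in place of the 3-fluorophenyl of compound 2, on an aromatic carbon ortho to a large group: 6-fluoropyridin-3-yl in place of 3-fluorophenyl on an aromatic carbon. Among the compounds with values here, only one measured step bears on this change, the modest 2.3-fold higher number from compound 1 to compound 2 (0.36 log units; beyond the scatter), in which 3-fluorophenyl replaces 4-fluorophenyl. Within the data shown here, that step involves rings of carbon only, and no measured pair shows the effect of exchanging 3-fluorophenyl for a pyridine ring. No step beyond the scatter is therefore expected in this assay, and no firm direction can be assigned. The estimated change is a 1.2-fold lower number from compound 2 to compound 3 (0.07 log units; within the scatter). For compound 3 the estimated value is 120 nM, with an expected range from 40 nM to 400 nM.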

Compound 3, half-maximal inhibitory concentration: 330 nM
Beside the measured number, compound 3's estimate is 2.8-fold (0.44 log units) below it, and the stated range covers the measured number.
By their numbers in this assay, from the lowest: compound 1; then compound 2; then compound 3.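

In this assay, the earlier pair moved fluorine around a ring of carbon only, whereas this result puts a ring nitrogen at the same aromatic carbon, ortho to a large group, and gives a 2.4-fold higher number from compound 2 to compound 3 (0.37 log units; beyond the scatter). The exchange of rings therefore moves the number by a step beyond the scatter, in the direction of a weaker inhibitor, and measured against the 4-fluorophenyl of the best compound of the three it amounts to a 5.4-fold higher number from compound 1 to compound 3 (0.73 log units; beyond the scatter), leaving compound 3 the weakest of the set. Nothing available explains why the pyridine ring gives the higher number.

As far as these compounds go, what a plain phenyl or a pyridin-3-yl without fluorine would give at this place stays open, so the share of the ring nitrogen and of the fluorine cannot be separated. Equally open, from the compounds shown here alone, is whether a methoxy group or an amine in place of the fluorine on the pyridine ring would recover any of the lost activity.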